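The source may hold more compounds than are shown below. What is called first, only, known or untested is meant among the compounds shown, and "the series" means these compounds.

Measured in a functional assay on aorta (Rattus norvegicus) for inhibition; a higher number here means that more compound is needed for the effect, a lower number that less compound is needed:
- compound 1 `CCNC1=NS(=O)(=O)c2cccc(Cl)c2N1`: 90400 nM
- compound 2 `CC(C)NC1=NS(=O)(=O)c2cccc(Cl)c2N1`: > 300000 nM (a limit of the assay, not a number)

Compound 2 has no number in this assay, so its standing is known only as a limit: the limit of > 300000 nM in this assay, at which 1 of the 2 values shown sits.

The next change leads to compound 3 `O=S1(=O)N=C(NC2CCC2)Nc2c(Cl)cccc21`, with cyclobutyl in place of isopropyl on an amine nitrogen.

Within the data shown here, the only measured step is an at least 3.3-fold higher number from compound 1 to compound 2 (0.52 log units; beyond the scatter). It alters the same substituent on the amine nitrogen as this change does. Its size is a bound and not a full measure. Among the measured compounds shown here, no measured step covers a ring at this place, so the direction rests on thin evidence.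

For the measured compounds named here, compound 1 gives 90400 nM, the only true number, and it serves as the reference for what this substituent place can reach. A modest move towards that number is expected for compound 3, although a second report of a limit remains about as likely as a number.

The expected change is an at least 2.0-fold lower number from compound 2 to compound 3 (0.30 log units; that floor lies within the scatter).

Compound 3 is estimated at 150000 nM, with an expected range of 50000 nM to 300000 nM.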

Compound 3, half-maximal effective concentration: 126000 nM
Beside the measured number, compound 3's estimate is 1.2-fold (0.08 log units) above it; low and high end bracket the measured number.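

In this assay, cyclobutyl in place of isopropyl on the amine nitrogen gives an at least 2.3-fold lower number from compound 2 to compound 3 (0.37 log units; beyond the scatter), so the loss seen with isopropyl is not shared by every replacement of ethyl at this place. Set against the ethyl group of compound 1, cyclobutyl gives a 1.4-fold higher number from compound 1 to compound 3 (0.14 log units; within the scatter), so no difference can be read between the ethyl chain and this ring of carbon only, and a ring at this place keeps the number in the range of the series' only earlier true value. Compound 2 remains a limit of the assay and not a number, so its step to the cyclobutyl compound gives a bound on the size of the change and not a full measure: the limit of > 300000 nM in this assay, at which 1 of the 3 values shown sits.

Still open, from the compounds shown here alone, is how the number in this assay would respond to ring size at this place, with cyclopropyl or cyclopentyl on the amine nitrogen, or to a longer chain such as n-propyl. Also open, going by these compounds, is whether a substituent carrying a hydroxyl or a carboxylic acid would move the number clearly away from the level shared by compound 1 and compound 3.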